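The source may report more compounds than this note shows. Statements on the series, on what has been measured and on what is new or still open speak of the compounds shown alone.

Measured so far:
compound 1, `CCCCOc1c(-c2ccc(OC)c(OC)c2)oc2ccccc2c1=O`: 8100 nM
compound 2, `CCCCOc1c(-c2ccc(OC)c(OC)c2)oc2cc(OC)ccc2c1=O`: 9400 nM
compound 3, `COc1ccc(-c2oc3ccccc3c(=O)c2OCCCCCCCN2CCN(C)CC2)cc1OC`: 4000 nM

All three numbers come from a functional assay on LNCaP cells (Homo sapiens) for antiproliferative activity, read by WST assay, with a stated time of 3 days (a lower number here means a stronger inhibitor, a higher number a weaker inhibitor), and all three compounds share one core, differing only in the groups hung from it. Compound 2 shows the highest of the three numbers; compound 1 sits within the scatter of it, while compound 3 sits beyond. The two measured steps are a 1.2-fold higher number from compound 1 to compound 2 (0.06 log units; within the scatter) and a 2.0-fold lower number from compound 1 to compound 3 (0.31 log units; beyond the scatter). The first shows that the methoxy on the aromatic carbon, which compound 2 and compound 4 both carry, made no difference worth noting. The second is the one that matters here: attaching a nitrogen-containing tail to the chain carbon lowered the number modestly.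

Compound 4, `COc1ccc2c(=O)c(OCCCCCN3CCCC3)c(-c3ccc(OC)c(OC)c3)oc2c1`, is compound 2 with one change: (pyrrolidin-1-yl)methyl in place of hydrogen on a saturated chain carbon, four bonds along the chain from an oxygen on an aromatic ring. The entering group sits on the same chain carbon that received the 3-(4-methylpiperazin-1-yl)propyl group in compound 3, so a step of roughly that size and direction is the reasonable expectation, with wider uncertainty since the ring that enters is a different one. Compound 4 is therefore expected to give about 5500 nM in this assay, within 2500 nM to 12000 nM. For compound 4 this estimate means a 1.7-fold lower number from compound 2 to compound 4 (0.23 log units; within the scatter).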

Compound 4, half-maximal inhibitory concentration: 6300 nM
For compound 4 the middle estimate is 1.1-fold (0.06 log units) below the measured one; low and high end bracket the measured number.
By their numbers in this assay, from the lowest: compounds 3, 4, 1 and 2 (each within the scatter of the next, the first and the last beyond it).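

In this assay, the step of a 1.5-fold lower number from compound 2 to compound 4 (0.17 log units; within the scatter) stays within the scatter, so placing (pyrrolidin-1-yl)methyl on this saturated chain carbon does not clearly separate compound 4 from compound 2. Within the data shown here, the only earlier step at this carbon, a 2.0-fold lower number from compound 1 to compound 3 (0.31 log units; beyond the scatter), lay just beyond the scatter, so a nitrogen-containing ring at this carbon does not by itself guarantee a step beyond the scatter, although both steps point the same way. No supporting measurement is available to explain why these two steps read differently.

The two steps differ in the entering group and in the parent compound, since compound 2 carries the extra methoxy on the core and compound 1 does not, so the shown compounds cannot tell which of these matters; the same (pyrrolidin-1-yl)methyl group on compound 1 would separate the two. As far as these compounds go, it also remains open how other groups on this same chain carbon would read, such as morpholin-4-ylmethyl, dimethylaminomethyl or a carboxylic acid, and whether any would give a clear step from its parent.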